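Amide Analogues Against Gastric Cancer Cells: Methoxy for Chloro

The source may hold more compounds than are shown below. What is called first, only, known or untested is meant among the compounds shown, and "the series" means these compounds.

Measured compounds in a functional assay on NUGC-3 cells (Homo sapiens) for inhibition, read by sulforhodamine B assay, with a stated time of 48 h (on this read-out lower numbers stand for stronger inhibition of growth and higher numbers for weaker inhibition of growth), each reported only as a limit of the assay and not as a number:
compound 1 `O=C(Nc1ccc(Cl)cc1)c1nccc2ccccc12`: > 10000 nM
compound 2 `O=C(Nc1cccc(Cl)c1)c1nccc2ccccc12`: > 10000 nM
compound 3 `COc1ccc(NC(=O)c2nccc3ccccc23)cc1`: > 10000 nM

Compound 2 has the same atoms as compound 1 joined differently; how the two cores differ is not broken down here. Compound 3 arises from compound 1 by methoxy in place of chloro on an aromatic carbon, and the step is a step that the two limits leave unreadable from compound 1 to compound 3. Its size stays hidden because of the limit of > 10000 nM in this assay, at which 3 of the 3 values shown sit. Compound 4 `COc1cccc(NC(=O)c2nccc3ccccc23)c1` is not yet measured; it arises from compound 2 by methoxy in place of chloro on an aromatic carbon, the same kind of change, though here the place is meta to a large group rather than para to a large group. The step from compound 2 to compound 4 is expected to be a step that the limit leaves unreadable from compound 2 to compound 4, resting on the limit given for compound 2 and on (the limit of > 10000 nM in this assay, at which 3 of the 3 values shown sit). Compound 4 is therefore estimated to give about 15000 nM in this assay, most likely again only as a limit.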

Compound 4, concentration for 50% growth inhibition: > 10000 nM
Compound 4: a limit, no number; the forecaster's own chance of this, stated with the estimate: 80%; the middle value lies beyond the limit too.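

Among the compounds shown here, compound 2 and compound 4 are both reported only as limits, so no step between them can be read: the limit of > 10000 nM in this assay, at which 4 of the 4 values shown sit. The compounds shown leave open whether methoxy or chloro, at either place, gives stronger inhibition of growth in this assay.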